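Amide Tail Variation on a Shared Pyrrole-Derived Core

The compounds below may be only part of what the source reports. "The series", "measured", "known", "first", "only" and "open" are said of these compounds alone.

Of the compounds shown here, three built on one core have been tested in a functional assay on PC-3 cells (Homo sapiens) for antiproliferative activity, read by MTT assay, with a stated time of 48 h; a higher number here means a weaker inhibitor, a lower number a stronger inhibitor. Compound 1 `CCn1c(C(=O)NCCN(C)C)ccc1C(CC)(CC)c1ccc(OCCC(O)(CC)CC)c(C)c1` gives 870 nM, compound 2 `C#CC(C)OC(=O)c1ccc(C(CC)(CC)c2ccc(OCCC(O)(CC)CC)c(C)c2)n1CC` gives 14800 nM, and compound 3 `CCOC(=O)CN(C)C(=O)c1ccc(C(CC)(CC)c2ccc(OCCC(O)(CC)CC)c(C)c2)n1CC` gives 7140 nM. Compound 3 stands second highest of the three numbers: the step of a 2.1-fold lower number from compound 2 to compound 3 (0.32 log units; beyond the scatter) places it nearer to compound 2, while the step of an 8.2-fold higher number from compound 1 to compound 3 (0.91 log units; beyond the scatter) separates it more widely from compound 1, the lowest number seen.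

Compound 4 `CCn1c(C(=O)N(C)CCO)ccc1C(CC)(CC)c1ccc(OCCC(O)(CC)CC)c(C)c1` differs from compound 3 in one place: hydroxymethyl in place of ethoxycarbonyl on a saturated chain carbon bound to an amide-type nitrogen. For the measured compounds named here, no measured step exchanges these two groups, so the bearing of the earlier steps is indirect. The step of a 17-fold higher number from compound 1 to compound 2 (1.23 log units; beyond the scatter) and the step of an 8.2-fold higher number from compound 1 to compound 3 (0.91 log units; beyond the scatter) show that the group carried on the carbonyl carbon moves this assay by large to modest amounts, and that exchanging a (2-(dimethylamino)ethyl)amino tail for other groups raises the number. Compound 4 keeps the methyl-bearing amide-type nitrogen of compound 3 and replaces only the outer part of its chain, so a step of modest size at most is expected, and its direction is uncertain; a small move toward the lower number of compound 1 is expected, a 1.6-fold lower number from compound 3 to compound 4 (0.20 log units; within the scatter). In this assay compound 4 is therefore expected to give 4500 nM, within a range from 1500 nM to 13000 nM.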

Compound 4, half-maximal inhibitory concentration: 3090 nM
Estimate against measurement, compound 4: 1.5-fold (0.16 log units) above; the measured number falls inside the stated range.
By their numbers in this assay, from the lowest: compound 1; then compound 4; then compound 3; then compound 2.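

In this assay, for the compounds shown here, hydroxymethyl in place of ethoxycarbonyl on a saturated chain carbon bound to an amide-type nitrogen gives a 2.3-fold lower number from compound 3 to compound 4 (0.36 log units; beyond the scatter), so with the methyl-bearing amide-type nitrogen held fixed, the outer part of the chain alone moves the number beyond the scatter, something the earlier steps could not show, as each of them exchanged the whole group on the carbonyl carbon. The (2-hydroxyethyl)(methyl)amino group closes only part of the range, with a 4.8-fold lower number from compound 2 to compound 4 (0.68 log units; beyond the scatter) on one side and a 3.6-fold higher number from compound 1 to compound 4 (0.55 log units; beyond the scatter) on the other, so the (2-(dimethylamino)ethyl)amino tail keeps the lowest number of the four. Nothing measured here gives a reason for these steps.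

The last of these steps changes both the amide hydrogen, which becomes a methyl, and the end of the chain, which leaves open how much of the gap belongs to each. Also open, going by these compounds, is where a carboxylic acid, a dimethylamino end on the methyl-bearing amide-type nitrogen, or a longer chain ending in a hydroxyl would fall in this order.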